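Swapping a Benzyl Substituent in Two Toll-like Receptor 9 Antagonists

The source may report more compounds than this note shows. Statements on the series, on what has been measured and on what is new or still open speak of the compounds shown alone.

Compound 1 `CCN1CCN(c2nc(NCc3ccc(F)cc3)nc3c2ncn3CCCN2CCCC2)CC1` — 40 nM
Compound 2 `CN(C)Cc1ccc(CNc2nc(N3CCN(C4CCCC4)CC3)c3ncn(CCCN4CCCC4)c3n2)cc1` — 7 nM

Of the compounds shown here, two have been measured in an assay on HEK293 cells for antagonist activity at Toll-like receptor 9 (Homo sapiens), read by spectrophotometry; a lower number here means a stronger inhibitor, a higher number a weaker inhibitor. Compound 2 gives 7 nM, the lowest of the two numbers, and compound 1 gives 40 nM, a gap that lies beyond the scatter. The two compounds differ in more than one place, so only their two values can be compared.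

Compound 3 `Fc1ccc(CNc2nc(N3CCN(C4CCCC4)CC3)c3ncn(CCCN4CCCC4)c3n2)cc1` has not yet been measured. It differs from compound 2 in one place: fluoro in place of (dimethylamino)methyl on an aromatic carbon. The fluoro group that enters is the one found on the benzyl group of compound 1. A step toward a higher number in this assay is expected, because compound 1 gives 40 nM with that same fluoro group. The step is estimated as a 3.6-fold higher number from compound 2 to compound 3 (0.55 log units; beyond the scatter). For compound 3 the expected value is 25 nM, within a range from 8 nM to 80 nM.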

Compound 3, half-maximal inhibitory concentration in the Toll-like receptor 9 assay: 100 nM
Compound 3: the middle estimate sits 4.0-fold (0.60 log units) below what was measured, outside the stated range (above it).
By their numbers in the Toll-like receptor 9 assay, from the lowest: compound 2; then compound 1; then compound 3.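

In the Toll-like receptor 9 assay the substituent on this aromatic carbon counts for much: fluoro in place of (dimethylamino)methyl gives a 14-fold higher number from compound 2 to compound 3 (1.15 log units; beyond the scatter) with the rest of the molecule held constant. The earlier pair could not separate the two changes, but cyclopentyl in place of ethyl on the ring amine nitrogen, with the 4-fluorobenzyl group kept, gives a smaller step, a 2.5-fold higher number from compound 1 to compound 3 (0.40 log units; beyond the scatter) (modest, yet beyond the scatter). In a physicochemical assay for solubility, with a stated time of 18 h, at pH 7.4 (on this read-out higher numbers stand for higher solubility and lower numbers for lower solubility), compound 2 gives 47.5 ug/mL and compound 3 gives 28 ug/mL, two values within the scatter of each other. Nothing measured here accounts for the large step.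

The compounds shown leave open whether a carboxylic acid, a plain methyl or a longer aminoalkyl chain at this place would track with the (dimethylamino)methyl result. They also leave open how ethyl on the ring amine nitrogen would read alongside (dimethylamino)methyl.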